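A Nitro Group in Place of Methyl

A few compounds are considered here, and "the series" means these few. Any claim that something is new, unique, unknown or untested is made for them only; others in the source may bear on it.

In a functional assay on NCI-H460 cells (Homo sapiens) for cytotoxicity (a lower number here means a stronger inhibitor, a higher number a weaker inhibitor), compound 3 (`Cc1ccc2nc(NC(=O)CCCCC(=O)NO)sc2c1`) gives 11 ug/mL. This lies within the scatter of compound 1 (`COc1ccc2nc(NC(=O)CCCCC(=O)NO)sc2c1`) at 21.4 ug/mL and well above compound 2 (`Cc1ccc2nc(NC(=O)CCCCCCC(=O)NO)sc2c1`) at 0.84 ug/mL. Compound 4 (`O=C(CCCCC(=O)Nc1nc2ccc([N+](=O)[O-])cc2s1)NO`) carries nitro in place of methyl on an aromatic carbon. For the measured compounds named here, the only measured exchange on an aromatic carbon is methyl in place of methoxy, a 1.9-fold lower number from compound 1 to compound 3 (0.29 log units; within the scatter). The large change, a 13-fold higher number from compound 2 to compound 3 (1.12 log units; beyond the scatter), lies on the saturated chain, which compound 4 shares with compound 3. Going by the values given here, no compound with nitro has been measured, so the range stays wide. The expected change is small, a 1.1-fold higher number from compound 3 to compound 4 (0.04 log units; within the scatter), and none beyond the scatter is expected. Compound 4 is estimated at 12 ug/mL, within a range of 4 ug/mL to 35 ug/mL.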

Compound 4, half-maximal inhibitory concentration: > 30 ug/mL
Compound 4: a limit, no number (the forecaster's own chance of this, stated with the estimate: 5%); middle value at least 2.5-fold (0.39 log units) from the limit.
By their numbers in this assay, from the lowest: compound 2; then compounds 3 and 1 (each within the scatter of the next). At a limit, above all of these: compound 4.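

In this assay, compound 4 is read only as a limit, not a number: the limit of > 30 ug/mL in this assay, at which 1 of the 4 values shown sits. Nitro in place of methyl on this aromatic carbon gives an at least 2.7-fold higher number from compound 3 to compound 4 (0.43 log units; beyond the scatter), so an exchange at this position can carry the number beyond the scatter, which the methoxy and methyl pair did not show. Nitro in place of methoxy gives an at least 1.4-fold higher number from compound 1 to compound 4 (0.14 log units; that floor lies within the scatter), a floor that by itself shows no separation. From the compounds shown here alone, how far compound 4 lies past its limit stays open. Going by these compounds, whether an amine or a carboxylic acid on this carbon would follow nitro or methyl also stays open.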